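Swapping one group among closely matched growth inhibitors

The source may hold more compounds than are shown below. What is called first, only, known or untested is meant among the compounds shown, and "the series" means these compounds.

In a functional assay on RS4-11 cells (Homo sapiens) for inhibition, read by CCK-8 assay, with a stated time of 48 h, tested at 20 uM (on this read-out lower numbers stand for less inhibition of growth and higher numbers for more inhibition of growth at the one concentration tested), compound 3 `N#C/C(=C\c1ccccc1OS(=O)(=O)c1ccc(Cl)cc1)C(=O)Nc1nnc(-c2cccc(F)c2)s1` gives 71%. Compound 2 `N#C/C(=C\c1ccccc1OS(=O)(=O)c1ccc(Cl)cc1)C(=O)Nc1nnc(Cc2ccccc2)s1` gives 73%, and compound 1 `N#C/C(=C\c1ccccc1OS(=O)(=O)c1ccc(F)cc1)C(=O)Nc1nnc(Cc2cccc3ccccc23)s1` gives 68%, so all three lie within the usual scatter of one another. Compound 4 `N#C/C(=C\c1ccccc1OS(=O)(=O)c1ccc(Cl)cc1)C(=O)Nc1nnc(Cc2ccc(Cl)cc2)s1` has not yet been measured. It differs from compound 3 at one place, with 4-chlorobenzyl in place of 3-fluorophenyl on an aromatic carbon. Among the measured compounds shown here, the only measured change at this place put 3-fluorophenyl in place of benzyl and gave a number 2 percentage points lower from compound 2 to compound 3 (within the scatter). With so little to go on, the expected result is no change at the digits printed from compound 3 to compound 4 (within the scatter), with no step beyond the scatter and no clear direction. For compound 4 the estimated value is 71%, with an expected range of 59% to 82%.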

Compound 4, percent growth inhibition at one concentration: 64%
Estimate against measurement, compound 4: 7 percentage points above; the range from low to high includes it.
By their numbers in this assay, from the lowest: compounds 4, 1, 3 and 2 (each within the scatter of the next).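

At this position, 4-chlorobenzyl in place of 3-fluorophenyl gives a number 7 percentage points lower from compound 3 to compound 4 (within the scatter), and chloro in place of hydrogen on the benzyl group gives a number 9 percentage points lower from compound 2 to compound 4 (within the scatter). Compound 4 therefore extends the earlier finding: across benzyl, 3-fluorophenyl and 4-chlorobenzyl, every listed step at this position remains within the scatter. Nothing available explains these numbers.

As far as these compounds go, whether the read-out would stay within the scatter with an amine or a carboxylic acid at this position remains open. So does the effect of a longer chain carrying the phenyl ring.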